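From Methyl to Piperidin-4-yl on the Amide Nitrogen

A few compounds are considered here, and "the series" means these few. Any claim that something is new, unique, unknown or untested is made for them only; others in the source may bear on it.

In a functional assay on U-87MG ATCC cells for inhibition, with U-87 MG (Homo sapiens) as the target, read by MTT assay, with a stated time of 72 h (a higher number here means a weaker inhibitor, a lower number a stronger inhibitor), compound 1 (`COc1ccccc1-c1csc2cnc(Nc3ccc(C(=O)NC4CCNCC4)c(C)c3)nc12`) gives 460 nM and compound 2 (`CNC(=O)c1ccc(Nc2ncc3scc(-c4ccccc4OC)c3n2)cc1`) gives 710 nM with the two values within the scatter of each other. On these numbers compound 2 cannot be told apart from compound 1. Compound 3 (`COc1ccccc1-c1csc2cnc(Nc3ccc(C(=O)NC4CCNCC4)cc3)nc12`) has not yet been measured. It differs from compound 2 by a single change (piperidin-4-yl in place of methyl on an amide-type nitrogen) with piperidin-4-yl in place of methyl on an amide-type nitrogen. For the measured compounds named here, no pair of measured compounds differing in one place shows what such a change does. Going by the values given here, the only guide is that compound 3 shares the piperidin-4-yl with compound 1, which gives 460 nM in this assay as the nearest available reading. A small move toward a lower number is therefore expected in this assay and none beyond the scatter. The estimated change is a step of a 1.8-fold lower number from compound 2 to compound 3 (0.25 log units; within the scatter) that stays within the usual scatter. For compound 3 the estimated value is 400 nM with an expected range from 130 nM to 1200 nM for four of five repeat measurements.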

Compound 3, half-maximal inhibitory concentration: 650 nM
Beside the measured number, compound 3's estimate is 1.6-fold (0.21 log units) below it, within the range that was stated.
By their numbers in this assay, from the lowest: compounds 1, 3 and 2 (each within the scatter of the next).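

In this assay, for the compounds shown here, piperidin-4-yl in place of methyl on an amide-type nitrogen brings a 1.1-fold lower number from compound 2 to compound 3 (0.04 log units; within the scatter), the first direct reading of this change: a group of 6 heavy atoms with one six-membered non-aromatic ring, 1 hydrogen-bond donor and 1 hydrogen-bond acceptor replaces a single carbon, and the two compounds still cannot be told apart. Going by these compounds alone, compound 3 also gives the first reading on the aromatic carbon that carries the methyl in compound 1, where hydrogen in place of methyl brings a 1.4-fold higher number from compound 1 to compound 3 (0.15 log units; within the scatter), so neither single change moves the number beyond the scatter in this assay. The data shown offer no measured explanation for either result.

Going by these compounds, it remains open whether this tolerance on the amide-type nitrogen extends to other groups there, such as a longer alkyl chain, an open-chain amine or a carboxylic acid. On these data alone, it is also open whether a group such as fluorine or chlorine on that aromatic carbon would behave as hydrogen and methyl do here.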